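Swapping the Aryl Group on the Ring Nitrogen of Compound 2

The source may hold more compounds than are shown below. What is called first, only, known or untested is meant among the compounds shown, and "the series" means these compounds.

In a functional assay on MKN-45 cells (Homo sapiens) for cytotoxicity, read by MTT assay, with a stated time of 72 h (on this read-out higher numbers stand for weaker inhibition and lower numbers for stronger inhibition), compound 1 `COc1cc2c(Oc3ccc(NC(=O)c4cn(-c5ccccc5OC)cn4)cc3F)ccnc2cc1OCCCN1CCCCC1` gives 260 nM, and compound 2 `COc1cc2c(Oc3ccc(NC(=O)c4cn(-c5ccccc5OC(F)(F)F)cn4)cc3F)ccnc2cc1OCCCN1CCCCC1` gives 190 nM. Compound 2 therefore sits at the lower of the two numbers, but the step of a 1.4-fold lower number from compound 1 to compound 2 (0.14 log units; within the scatter) keeps it within the scatter of compound 1. Compound 3 `COc1cc2c(Oc3ccc(NC(=O)c4cn(-c5ccc(Cl)cc5)cn4)cc3F)ccnc2cc1OCCCN1CCCCC1` carries 4-chlorophenyl in place of 2-(trifluoromethoxy)phenyl on an aromatic nitrogen. For the measured compounds named here, the one measured step touching this aryl group is that small one, so no change beyond the scatter is expected for compound 3, with a 1.3-fold higher number from compound 2 to compound 3 (0.12 log units; within the scatter). Compound 3 is accordingly estimated at 250 nM, between 80 nM and 800 nM.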

Compound 3, half-maximal inhibitory concentration: 5910 nM
Compound 3: the middle estimate sits 24-fold (1.37 log units) below what was measured, outside the stated range (above it).
By their numbers in this assay, from the lowest: compounds 2 and 1 (each within the scatter of the next); then compound 3.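

In this assay, the aryl group on the aromatic nitrogen turns out to matter a great deal: 4-chlorophenyl in place of 2-(trifluoromethoxy)phenyl gives a 31-fold higher number from compound 2 to compound 3 (1.49 log units; beyond the scatter), and 4-chlorophenyl in place of 2-methoxyphenyl gives a 23-fold higher number from compound 1 to compound 3 (1.36 log units; beyond the scatter). The tolerance seen earlier therefore covered only the exchange on the oxygen, not replacement of the whole aryl group. Nothing available explains this drop.

The compounds shown leave open whether the drop belongs to the loss of the oxygen-linked group or to the arrival of chlorine, two changes that come together here. Going by these compounds, how an unsubstituted phenyl group would read also remains open.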